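Removing the Nitrogen Methyl from a Diaryl Urea

This account rests on a few compounds, and the source may have more. Where it says the series, first, only, none or still open, it means among the compounds named here.

Compound 1 `CCc1cc(NC(=O)Nc2cccc(C(F)(F)F)c2)cc(Cl)c1Oc1cc(NC)ncn1` gives 100 nM in an assay on HEK cells for inhibition of serine/threonine-protein kinase TNNI3K (Homo sapiens), with stated times of 30 min and 20 min; a higher number here means a weaker inhibitor, a lower number a stronger inhibitor.
Compound 2 `CNc1cc(Oc2ccc(NC(=O)Nc3cccc(C(F)(F)F)c3)cc2)ncn1` gives 20 nM in this assay.
Compound 3 `CNc1cc(Oc2c(C)cc(NC(=O)Nc3cccc(C(F)(F)F)c3)cc2C)ncn1` gives 7.9 nM in this assay.

Among these three, compound 2 holds the second highest number: compound 1 sits higher and compound 3 lower, and both gaps lie beyond the scatter. Compound 4 `Nc1cc(Oc2ccc(NC(=O)Nc3cccc(C(F)(F)F)c3)cc2)ncn1` has not yet been measured. It differs from compound 2 in one place: hydrogen in place of methyl on a nitrogen on an aromatic ring. Within the data shown here, no measured pair here shows this change, so the expectation rests on compound 2 and the change itself. A small step is expected, a 1.6-fold higher number from compound 2 to compound 4 (0.20 log units; within the scatter), towards a higher number in this assay, one that may well stay within the scatter. Compound 4 is therefore estimated at 32 nM, between 10 nM and 100 nM.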

Compound 4, half-maximal inhibitory concentration: 16 nM
For compound 4 the middle estimate is 2.0-fold (0.30 log units) above the measured one, and the stated range covers the measured number.
By their numbers in this assay, from the lowest: compound 3; then compounds 4 and 2 (each within the scatter of the next); then compound 1.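

In this assay, the change from methylamino to amino gives a 1.3-fold lower number from compound 2 to compound 4 (0.10 log units; within the scatter), so the two compounds cannot be told apart. Among these compounds, this is the first direct reading at this nitrogen, and it shows that in this pair the methyl is not needed to keep the number at this level.

Still open, as far as these compounds go, is whether a longer chain such as ethyl, or an acetyl group, on this nitrogen would also leave the number in place. From the compounds shown here alone, it is equally open whether the same change would read alike on the core of compound 3. No measurement shown here speaks to why this pair reads as it does.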